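Octyl Ester Replaces Phenyl Ester in Thromboxane Synthase Series

A few compounds are considered here, and "the series" means these few. Any claim that something is new, unique, unknown or untested is made for them only; others in the source may bear on it.

Compound 2 `COc1ccc(COCC(Cn2ccnc2)OCc2ccc(C(=O)Oc3ccccc3)cc2)cc1` gives 560 nM in a functional assay for inhibition of Thromboxane-A synthase (Homo sapiens) (a higher number here means a weaker inhibitor, a lower number a stronger inhibitor), the highest of the two numbers measured, with compound 1 `CCCOC(=O)c1ccc(COC(COCc2ccc(OC)cc2)Cn2ccnc2)cc1` giving 180 nM. Compound 3 `CCCCCCCCOC(=O)c1ccc(COC(COCc2ccc(OC)cc2)Cn2ccnc2)cc1` differs from compound 2 by octyl in place of phenyl on an oxygen next to a carbonyl group. Within the data shown here, the one step that bears on this change is a 3.1-fold higher number from compound 1 to compound 2 (0.49 log units; beyond the scatter), which replaced an alkyl ester with the phenyl ester. Returning to an alkyl ester, now octyl, is therefore expected to lower the number, an expected step of a 2.2-fold lower number from compound 2 to compound 3 (0.35 log units; beyond the scatter). Compound 3 is estimated at 250 nM, within 100 nM to 700 nM.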

Compound 3, half-maximal inhibitory concentration: 21000 nM
Compound 3: middle estimate off by 84-fold (1.92 log units), on the low side, outside the stated range (above it).
By their numbers in this assay, from the lowest: compound 1; then compound 2; then compound 3.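

Octyl in place of phenyl on the oxygen next to a carbonyl group brings a 38-fold higher number from compound 2 to compound 3 (1.57 log units; beyond the scatter) in this assay and so an alkyl ester is not in itself better than the phenyl ester at this position. The length of the chain also counts, with octyl in place of propyl bringing a 120-fold higher number from compound 1 to compound 3 (2.07 log units; beyond the scatter) as the largest step among these compounds. Nothing available explains this rise. The compounds shown leave open where between propyl and octyl the number climbs, as a butyl or hexyl ester would show, and how a benzyl ester compares with the phenyl ester.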